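The source may report more compounds than this note shows. Statements on the series, on what has been measured and on what is new or still open speak of the compounds shown alone.

Measured so far in a functional assay on HCT-116 cells (Homo sapiens) for antiproliferative activity, read by CCK-8 assay, with a stated time of 72 h, tested at 2 uM; a lower number here means a weaker effect, a higher number a stronger effect of the compound at the concentration tested:
compound 1 `Nc1ccccc1NC(=O)/C=C/c1ccc(Cn2cnc3c(Nc4cccc(Cl)c4)nc(Cl)nc32)cc1` gives 12.9%;
compound 2 `Nc1ccccc1NC(=O)/C=C/c1ccc(Cn2cnc3c(NCc4ccccc4)nc(Cl)nc32)cc1` gives 2.85%;
compound 3 `Nc1ccccc1NC(=O)c1ccc(Cn2cnc3c(Nc4cccc(OC(F)(F)F)c4)nc(Cl)nc32)cc1` gives 1.6%.

Compound 3 has the lowest of the three numbers; compound 2 is within the scatter of it, and compound 1 stands clearly higher. Compound 4 `Nc1ccccc1NC(=O)/C=C/c1ccc(Cn2cnc3c(Nc4cccc(OC(F)(F)F)c4)nc(Cl)nc32)cc1` differs from compound 3 in one place: 2-((2-aminophenyl)carbamoyl)ethenyl in place of (2-aminophenyl)carbamoyl on an aromatic carbon. Among the compounds with values here, no measured step covers this change; the only step known, a number 10.1 percentage points lower from compound 1 to compound 2 (beyond the scatter), concerns a different part of the shared core. Compound 1 carries the same 2-((2-aminophenyl)carbamoyl)ethenyl group and gives 12.9%, so a rise is plausible but uncertain. A step of a number 7.4 percentage points higher from compound 3 to compound 4 (within the scatter) is expected, and compound 4 is estimated at 9%, between 0% and 25%.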

Compound 4, a percentage reported as inhibition, at one concentration (the size of the read-out at that concentration, not a potency): 2.8%
For compound 4 the middle estimate is 6.2 percentage points above the measured one, and the stated range covers the measured number.
By their numbers in this assay, from the lowest: compounds 3, 4 and 2 (each within the scatter of the next); then compound 1.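

In this assay, placing 2-((2-aminophenyl)carbamoyl)ethenyl where (2-aminophenyl)carbamoyl stood does not by itself separate the two compounds, with a number 1.2 percentage points higher from compound 3 to compound 4 (within the scatter). The group's presence in compound 1 therefore does not carry that compound's number over: trifluoromethoxy in place of chloro gives a number 10.1 percentage points lower from compound 1 to compound 4 (beyond the scatter), so the small aromatic substituent also counts here. Replacing benzyl with 3-(trifluoromethoxy)phenyl gives a number 0.1 percentage points lower from compound 2 to compound 4 (within the scatter). Nothing measured here offers a reason for these numbers. Still open, as far as these compounds go, is how compound 1 would respond to bromo or methyl in place of its chloro, or to a saturated ethyl link in place of the ethenyl.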